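From Compound 3 to Its 4-Chlorophenyl Counterpart

A few compounds are considered here, and "the series" means these few. Any claim that something is new, unique, unknown or untested is made for them only; others in the source may bear on it.

Three compounds sharing one core have numbers in a functional assay on HL-60 cells (Homo sapiens) for antiproliferative activity, read by MTT assay, with a stated time of 72 h; on this read-out higher numbers stand for weaker inhibition and lower numbers for stronger inhibition. Compound 1 `NC1=NC2(CCSCC2)N(OCCCOc2ccccc2Br)C(N)=N1` reads 180 nM there, compound 2 `NC1=NC2(CCSCC2)N(OCCCOc2ccccc2Cl)C(N)=N1` reads 390 nM and compound 3 `NC1=NC2(CCSCC2)N(OCCCOc2cccc(Br)c2)C(N)=N1` reads 200 nM on the same read-out. Compound 3 holds the middle of these three numbers, and its gap to each of the other two lies within the scatter.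

Compound 4 `NC1=NC2(CCSCC2)N(OCCCOc2ccc(Cl)cc2)C(N)=N1` carries 4-chlorophenyl in place of 3-bromophenyl on an oxygen on a saturated carbon. For the measured compounds named here, two measured steps bear on this change. Chloro in place of bromo on an aromatic carbon gave a modest step (a 2.2-fold higher number from compound 1 to compound 2 (0.34 log units; beyond the scatter)), while 3-bromophenyl in place of 2-bromophenyl gave a step within the scatter (a 1.1-fold higher number from compound 1 to compound 3 (0.05 log units; within the scatter)). Going by the values given here, the 4-chlorophenyl group itself has no measured precedent here, which leaves the estimate loose. A step to a higher number, no larger than the chloro step, is therefore expected (a 1.8-fold higher number from compound 3 to compound 4 (0.24 log units; within the scatter)) in this assay. For compound 4 the estimated value is 350 nM, with an expected range (150 nM to 800 nM).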

Compound 4, half-maximal inhibitory concentration: 430 nM
For compound 4 the middle estimate is 1.2-fold (0.09 log units) below the measured one, within the range that was stated.
By their numbers in this assay, from the lowest: compounds 1, 3, 2 and 4 (each within the scatter of the next, the first and the last beyond it).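

In this assay, for the compounds shown here, the 4-chlorophenyl group gives the first comparison of two chlorophenyl groups on this oxygen, and 4-chlorophenyl in place of 2-chlorophenyl gives a small step (a 1.1-fold higher number from compound 2 to compound 4 (0.04 log units; within the scatter)). Set against the bromophenyl compounds, the same group gives larger steps (a 2.2-fold higher number from compound 3 to compound 4 (0.33 log units; beyond the scatter); a 2.4-fold higher number from compound 1 to compound 4 (0.38 log units; beyond the scatter)), so these comparisons follow the halogen more closely than its ring position, although one comparison goes against a clean split (a 2.0-fold lower number from compound 2 to compound 3 (0.29 log units; within the scatter)). No supporting measurement accounts for these steps.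

3-bromophenyl and 4-chlorophenyl differ in both halogen and ring position. A 4-bromophenyl or 3-chlorophenyl group would be needed to separate the two changes. From the compounds shown here alone, whether the pattern extends to a fluorophenyl group, an unsubstituted phenyl ring or a longer chain before the phenoxy oxygen remains open.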